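From methoxymethyl to carbamoyl on a saturated ring

The source may hold more compounds than are shown below. What is called first, only, known or untested is meant among the compounds shown, and "the series" means these compounds.

Measured so far in an ADME assay on microsomes from liver (Rattus norvegicus) for metabolic stability; on this read-out lower numbers stand for a less stable compound and higher numbers for a more stable compound
Compound 1 `CCCCCOC(=O)N1CCN(C(=O)[C@H](CCC(=O)O)NC(=O)c2cc(N3CCC(C(=O)NCC)CC3)nc(-c3ccccc3)n2)CC1` gives > 80% (a limit)
Compound 2 `CCCCCOC(=O)N1CCN(C(=O)[C@H](CCC(=O)O)NC(=O)c2cc(N3CCC(OCCO)CC3)nc(-c3ccccc3)n2)CC1` gives > 80% (a limit)
Compound 3 `CCCCCOC(=O)N1CCN(C(=O)[C@H](CCC(=O)O)NC(=O)c2cc(N3CCC(COC)CC3)nc(-c3ccccc3)n2)CC1` gives > 80% (a limit)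

Compound 3 shows > 80% as a limit, not a number. The whole evidence so far is the limit of > 80% in this assay, at which 3 of the 3 values shown sit, and nothing finer.

Compound 4 `CCCCCOC(=O)N1CCN(C(=O)[C@H](CCC(=O)O)NC(=O)c2cc(N3CCC(C(N)=O)CC3)nc(-c3ccccc3)n2)CC1` comes from compound 3 by one change carbamoyl in place of methoxymethyl on a saturated ring carbon with carbamoyl in place of methoxymethyl on a saturated ring carbon. Swaps at that ring carbon have been measured as a step that the two limits leave unreadable from compound 1 to compound 2 and a step that the two limits leave unreadable from compound 1 to compound 3 and a step that the two limits leave unreadable from compound 2 to compound 3 so none of them has a readable size. Compound 1 carries ethylcarbamoyl, the measured group closest to carbamoyl, and shows > 80% as a limit.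

No step beyond the usual scatter is therefore expected in this assay in either direction. The expected change is a step that the limit leaves unreadable from compound 3 to compound 4 as an estimate. Compound 4 is expected at 88% with an estimated range from 75% to 100% and may again end up only as a limit.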

Compound 4, percent of the compound remaining: > 80%
Compound 4: only a limit was reported; the forecaster's own chance of this, stated with the estimate: 80%; the middle value does not contradict the limit.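

In this assay compound 4 gives > 80% as a limit. Its steps from compound 1, compound 2 and compound 3 cannot be read. How far the four groups on the saturated ring carbon differ in this read-out stays open, because the evidence holds only this: the limit of > 80% in this assay, at which 4 of the 4 values shown sit.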